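Piperidine to Pyrrolidine on the Side Chain of Compound 3

This account rests on a few compounds, and the source may have more. Where it says the series, first, only, none or still open, it means among the compounds named here.

Measured compounds in a functional assay on HT-29 cells (Homo sapiens) for cytotoxicity, read by MTT assay, with a stated time of 72 h; a lower number here means a stronger inhibitor, a higher number a weaker inhibitor:
compound 1 `COc1cc2c(Oc3ccc(NC(=O)c4cc(-c5ccc(F)cc5)ccn4)cc3F)ccnc2cc1OCCCN1CCCCC1`: 1370 nM
compound 2 `COc1cc2c(Oc3ccc(NC(=O)c4cc(-c5ccccc5F)ccn4)cc3F)ccnc2cc1OCCCN1CCCCC1`: 320 nM
compound 3 `COc1ccc(-c2ccnc(C(=O)Nc3ccc(Oc4ccnc5cc(OCCCN6CCCCC6)c(OC)cc45)c(F)c3)c2)cc1`: 690 nM

Compound 3 sits second highest of the three. Its nearest neighbour is compound 1, with a 2.0-fold lower number from compound 1 to compound 3 (0.30 log units; within the scatter); its furthest is compound 2, with a 2.2-fold higher number from compound 2 to compound 3 (0.33 log units; beyond the scatter). Compound 4 `COc1ccc(-c2ccnc(C(=O)Nc3ccc(Oc4ccnc5cc(OCCCN6CCCC6)c(OC)cc45)c(F)c3)c2)cc1` differs from compound 3 in one place: pyrrolidin-1-yl in place of piperidin-1-yl on a saturated chain carbon, three bonds along the chain from an oxygen on an aromatic ring. For the measured compounds named here, none of the measured steps bears on this site; the steps of a 4.3-fold lower number from compound 1 to compound 2 (0.63 log units; beyond the scatter) and a 2.2-fold higher number from compound 2 to compound 3 (0.33 log units; beyond the scatter) both change the aryl group on the other end of the molecule and leave the basic side chain untouched. Going by the values given here, with no relevant precedent, the expectation for compound 4 is a step of no change at the digits printed from compound 3 to compound 4 (within the scatter), that is, nothing beyond the scatter. Compound 4 is therefore estimated at 690 nM, with a range from 300 nM to 1600 nM.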

Compound 4, half-maximal inhibitory concentration: 350 nM
Compound 4: the middle estimate sits 2.0-fold (0.29 log units) above what was measured; the measured number falls inside the stated range.
By their numbers in this assay, from the lowest: compounds 2, 4, 3 and 1 (each within the scatter of the next, the first and the last beyond it).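

In this assay, the basic side chain is varied for the only time among these compounds, and pyrrolidin-1-yl in place of piperidin-1-yl gives a 2.0-fold lower number from compound 3 to compound 4 (0.29 log units; within the scatter). For the compounds shown here, the earlier steps changed only the aryl group, so this is the sole reading at this position, and it shows that this ring change leaves the number within the scatter. Nothing available accounts for this step.

As far as these compounds go, whether morpholin-4-yl or dimethylamino in the same place, or a longer chain, would read alike remains open. So does whether the same change would read alike with the 2-fluorophenyl group of compound 2.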